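This account rests on a few compounds, and the source may have more. Where it says the series, first, only, none or still open, it means among the compounds named here.

In a functional assay on HepG2 cells (Homo sapiens) for inhibition, read by MTT assay, with a stated time of 72 h (a lower number here means a stronger inhibitor, a higher number a weaker inhibitor), compound 1 `Brc1ccc(-c2nnc(SCCCN3CCN(c4nc5ccccc5o4)CC3)o2)cc1` gives 67500 nM and compound 2 `Oc1ccc(-c2nnc(SCCCN3CCN(c4nc5ccccc5o4)CC3)o2)cc1` gives 502000 nM, so compound 1 has the lower of the two numbers and is the stronger inhibitor of the pair. Compound 3 `Brc1ccc(-c2nnc(SCCCN3CCN(c4nc5ccccc5s4)CC3)o2)cc1` keeps the bromo group of compound 1 but carries 1,3-benzothiazol-2-yl in place of 1,3-benzoxazol-2-yl on an amine nitrogen in a ring. Among the compounds with values here, the only measured step, a 7.4-fold higher number from compound 1 to compound 2 (0.87 log units; beyond the scatter), swaps bromo for hydroxy at a different place, so it offers just a rough yardstick and no direct guide to this change. With sulfur replacing oxygen and the rest of the molecule unchanged, the expected step is a 1.1-fold lower number from compound 1 to compound 3 (0.05 log units; within the scatter), with no direction favoured and nothing expected beyond the scatter. Compound 3 is therefore estimated at 60000 nM, with an expected range of 22000 nM to 170000 nM.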

Compound 3, half-maximal inhibitory concentration: 103000 nM
Compound 3: middle estimate off by 1.7-fold (0.23 log units), on the low side; low and high end bracket the measured number.
By their numbers in this assay, from the lowest: compounds 1 and 3 (each within the scatter of the next); then compound 2.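

Placing 1,3-benzothiazol-2-yl in place of 1,3-benzoxazol-2-yl on the amine nitrogen in the ring gives a 1.5-fold higher number from compound 1 to compound 3 (0.18 log units; within the scatter) in this assay, so the two compounds cannot be told apart in this test. Within the data shown here, this is the first look at this position, and with the bromo group held fixed, sulfur and oxygen in this ring give numbers within the scatter of each other. No measurement at hand accounts for this result.

Going by these compounds, whether a smaller group on the same nitrogen, such as plain phenyl or pyridin-2-yl, would also stay within the scatter remains open. Also open, on these data alone, is whether the step seen on going from bromo to hydroxy, a 7.4-fold higher number from compound 1 to compound 2 (0.87 log units; beyond the scatter), would look the same with 1,3-benzothiazol-2-yl in place.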